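Branched acid side chains: compound 3 to compound 4

The compounds below may be only part of what the source reports. "The series", "measured", "known", "first", "only" and "open" are said of these compounds alone.

Measured so far in a physicochemical assay for lipophilicity, at pH 7.4; a lower number here means a more polar compound, a higher number a more lipophilic compound
- compound 1 `O=C(O)Cc1nn(Cc2cn3cc(OCC4CC4)c(Cl)cc3n2)c2ccccc2c1=O`: 2.13
- compound 2 `O=C(O)C1(c2nn(Cc3cn4cc(OCC5CC5)c(Cl)cc4n3)c3ccccc3c2=O)CC1`: 2.46
- compound 3 `CC(C)(C(=O)O)c1nn(Cc2cn3cc(OCC4CC4)c(Cl)cc3n2)c2ccccc2c1=O`: 2.95

Compound 3 stands highest of the three at 2.95 and both gaps to it lie beyond the scatter. Going to compound 4 `CCC(C(=O)O)c1nn(Cc2cn3cc(OCC4CC4)c(Cl)cc3n2)c2ccccc2c1=O` brings 1-carboxypropyl in place of 1-carboxy-1-methylethyl on an aromatic carbon with the same atoms joined differently. Three modest measured steps bear on this: a number 0.82 log units higher from compound 1 to compound 3 (beyond the scatter) and a number 0.49 log units higher from compound 2 to compound 3 (beyond the scatter) both end at the highest number, and a number 0.33 log units higher from compound 1 to compound 2 (beyond the scatter) shows a smaller rise. Among the measured compounds shown here, no measured pair isolates this exact rearrangement. A small downward step a number 0.20 log units lower from compound 3 to compound 4 (within the scatter) is therefore expected in this assay and it may not clear the scatter. The estimated value for compound 4 is 2.75 within an expected range of 2.4 to 3.1 on this scale.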

Compound 4, distribution coefficient: 2.71
The estimate for compound 4 lay 0.04 log units above the measured number; low and high end bracket the measured number.
By their numbers in this assay, from the lowest: compound 1; then compounds 2, 4 and 3 (each within the scatter of the next, the first and the last beyond it).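

In this assay the same atoms rearranged as 1-carboxypropyl give a number 0.24 log units lower from compound 3 to compound 4 (within the scatter), and against the cyclopropyl acid they give a number 0.25 log units higher from compound 2 to compound 4 (within the scatter), so at this position the new isomer is not separated from either of the other branched acids. Ethyl in place of hydrogen on the saturated chain carbon is enough to give a number 0.58 log units higher from compound 1 to compound 4 (beyond the scatter). Nothing at hand accounts for these steps. Open, on these data alone, is how a chain longer than ethyl on that carbon, or an amide in place of the carboxylic acid, would read in this assay.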